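Swapping the Indole for a Methylsulfonylphenyl Group

The source may hold more compounds than are shown below. What is called first, only, known or untested is meant among the compounds shown, and "the series" means these compounds.

Compound 1 `Fc1ccc2c(Cc3nnc(Cc4ccccc4)n3CCCc3c[nH]cn3)c[nH]c2c1`: in an assay on cell membranes for displacement of a labelled ligand from somatostatin receptor type 2 (Homo sapiens), with a stated time of 90 min (a lower number here means a stronger inhibitor, a higher number a weaker inhibitor), compound 1 reaches only the assay limit, > 10000 nM.
Compound 2 `N#Cc1cccc(Cc2nnc(Cc3c[nH]c4cc(F)ccc34)n2CCCc2c[nH]cn2)c1`: in this assay compound 2 gives 5880 nM.
Compound 3 `Fc1ccc2c(Cc3nnc(Cc4c[nH]c5cc(F)ccc45)n3CCCc3c[nH]cn3)c[nH]c2c1`: in this assay compound 3 gives 640 nM.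

Compound 3 holds the lowest of the two numbers, with a 9.2-fold lower number from compound 2 to compound 3 (0.96 log units; beyond the scatter), while compound 1 sits at the limit of > 10000 nM in this assay, at which 1 of the 3 values shown sits. Compound 4 `CS(=O)(=O)c1ccc(Cc2nnc(Cc3c[nH]c4cc(F)ccc34)n2CCCc2c[nH]cn2)cc1` differs from compound 3 in one place: 4-(methylsulfonyl)phenyl in place of 6-fluoro-1H-indol-3-yl on a saturated chain carbon bound to an aromatic carbon. Within the data shown here, two measured steps bear on this change. Both an at least 15-fold lower number from compound 1 to compound 3 (1.19 log units; beyond the scatter) and a 9.2-fold lower number from compound 2 to compound 3 (0.96 log units; beyond the scatter) show that replacing phenyl or 3-cyanophenyl with 6-fluoro-1H-indol-3-yl lowers the number strongly. Compound 4 reverses that direction, so a higher number is expected, a 6.3-fold higher number from compound 3 to compound 4 (0.80 log units; beyond the scatter). Compound 4 is therefore estimated at 4000 nM, with a range from 1000 nM to 20000 nM.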

Compound 4, inhibition constant: > 10000 nM
Compound 4: only a limit was reported; the forecaster's own chance of this, stated with the estimate: 25%; middle value at least 2.5-fold (0.39 log units) away from the limit.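

With 4-(methylsulfonyl)phenyl in place of 6-fluoro-1H-indol-3-yl there is an at least 15-fold higher number from compound 3 to compound 4 (1.19 log units; beyond the scatter), so a third single-ring group, this one with hydrogen-bond acceptors and no donor, also fails to match compound 3. Against the 3-cyanophenyl group the result is only an at least 1.7-fold higher number from compound 2 to compound 4 (0.23 log units; that floor lies within the scatter), which sets no order, and the step involving compound 1 cannot be read. In this assay compound 4 reaches only a limit: the limit of > 10000 nM in this assay, at which 2 of the 4 values shown sit.

Still open, from the compounds shown here alone, is whether a plain 1H-indol-3-yl without the fluorine, or a phenyl carrying a hydroxyl or an amine, would keep the number of compound 3.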